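The source may hold more compounds than are shown below. What is called first, only, known or untested is meant among the compounds shown, and "the series" means these compounds.

Measured compounds in a functional assay on MDA-MB-435 cells (Homo sapiens) for cytotoxicity, read by MTT assay, with a stated time of 72 h; a higher number here means a weaker inhibitor, a lower number a stronger inhibitor:
- compound 1 `COC(=O)c1nc(Br)c2cccnc2c1N[C@H]1CC[C@H](N)CC1`: > 20000 nM, a limit of the assay
- compound 2 `O=C(NCCCNc1c(C(=O)NCc2ccc(F)cc2)nc(Br)c2cccnc12)c1ccccc1`: > 20000 nM, a limit of the assay
- compound 3 `NCCCNc1c(C(=O)NCc2ccc(F)cc2)nc(Br)c2cccnc12`: 5000 nM

Compound 1 stands at the limit of this assay, so only a bound and no number is known for it. Within the data shown here, the same holds for compound 2, and the limit of > 20000 nM in this assay, at which 2 of the 3 values shown sit, is the state of the series so far. Among the measured compounds shown here, compound 3 is the only compound with a measured number.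

Compound 4 `N[C@H]1CC[C@H](Nc2c(C(=O)NCc3ccccc3)nc(Br)c3cccnc23)CC1` keeps the core of compound 1 together with its amine-bearing cyclohexyl group and differs in one place: benzylamino in place of methoxy on a carbonyl carbon. For the measured compounds named here, no measured step touches the carbonyl carbon, so none bears directly on this change. Going by the values given here, the single measured step, an at least 4.0-fold lower number from compound 2 to compound 3 (0.60 log units; beyond the scatter), concerns the amine nitrogen of the side chain and shows that the free amine is the state in which a number appears. Compound 4 carries a free amine and an amide bearing a benzyl group, as compound 3 does, and compound 3 gives 5000 nM in this assay.

The expectation is therefore that compound 4 leaves the limit region and lands near the number of compound 3. Compound 4 is estimated at 5000 nM, within 1500 nM to 20000 nM, which is the expected step of an at least 4.0-fold lower number from compound 1 to compound 4 (0.60 log units; beyond the scatter).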

Compound 4, half-maximal inhibitory concentration: 7000 nM
Compound 4: the middle estimate sits 1.4-fold (0.15 log units) below what was measured, within the range that was stated.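

In this assay, the carbonyl carbon now proves to be a place where a change moves the number: benzylamino in place of methoxy gives an at least 2.8-fold lower number from compound 1 to compound 4 (0.45 log units; beyond the scatter). The value of compound 1, > 20000 nM, is a limit, so this step fixes only a minimum size and not the full size. With the core and the amine-bearing cyclohexyl group held constant, the free amine alone does not yield a number in this pair, which adds a second place of influence to the amine nitrogen of the side chain seen in an at least 4.0-fold lower number from compound 2 to compound 3 (0.60 log units; beyond the scatter).

Open, on these data alone, is whether a smaller group such as methylamino, or a free carboxylic acid, on the carbonyl carbon would also leave the limit, and so whether the aromatic ring of benzylamino is needed for the step. Also open is what a longer chain in place of the cyclohexyl group would do on the benzylamino amide, while the series remains bounded at its weak end: the limit of > 20000 nM in this assay, at which 2 of the 4 values shown sit.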